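Swapping the piperazine substituent in a chalcone-triazole series

This account rests on a few compounds, and the source may have more. Where it says the series, first, only, none or still open, it means among the compounds named here.

Compound 1 `CCCCCCCCn1cc(/C=C/C(=O)c2ccc(NC(=O)CN3CCN(c4ccccc4)CC3)cc2)nn1`: 41400 nM
Compound 2 `CCCCCCCCCCn1cc(/C=C/C(=O)c2ccc(NC(=O)CN3CCN(c4ccccc4)CC3)cc2)nn1`: 39500 nM
Compound 3 `O=C(CN1CCN(c2ccccc2)CC1)Nc1ccc(C(=O)/C=C/c2cn(Cc3ccc(Br)cc3)nn2)cc1`: 72400 nM

In a functional assay on SK-N-SH cells (Homo sapiens) for inhibition, read by MTT assay (on this read-out lower numbers stand for stronger inhibition and higher numbers for weaker inhibition), compound 2 gives 39500 nM, the lowest of the three numbers, though the steps to both other compounds stay within the scatter: a 1.0-fold lower number from compound 1 to compound 2 (0.02 log units; within the scatter) and a 1.8-fold higher number from compound 2 to compound 3 (0.26 log units; within the scatter). The third measured step, a 1.7-fold higher number from compound 1 to compound 3 (0.24 log units; within the scatter), is likewise within the scatter. All three measured changes sit at the carbon bound to the triazole nitrogen, and none of them moves the number beyond the scatter.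

Compound 4 `CCCCCCCCCCn1cc(/C=C/C(=O)c2ccc(NC(=O)CN3CCN(C(=O)OC(C)(C)C)CC3)cc2)nn1` differs from compound 2 elsewhere: tert-butoxycarbonyl in place of phenyl on an amine nitrogen in a ring. Within the data shown here, no measured step touches this ring nitrogen, so none of the three steps bears on the change; they only show that the shared core of compound 2 tolerates variation at the other end without a shift beyond the scatter. Among the measured compounds shown here, with no direct precedent, a step of no clear direction is expected in this assay, and compound 4 is estimated at 50000 nM (range 15000 nM to 160000 nM). The expected step is a 1.3-fold higher number from compound 2 to compound 4 (0.10 log units; within the scatter), which lies within the scatter.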

Compound 4, half-maximal inhibitory concentration: 77800 nM
The estimate for compound 4 lay 1.6-fold (0.19 log units) below the measured number; the measured number falls inside the stated range.
By their numbers in this assay, from the lowest: compounds 2, 1, 3 and 4 (each within the scatter of the next).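

Among these compounds, until now every measured step sat at the carbon bound to the triazole nitrogen; this is the first step at the other end of the molecule, on an amine nitrogen in the six-membered ring. In this assay, tert-butoxycarbonyl in place of phenyl gives a 2.0-fold higher number from compound 2 to compound 4 (0.29 log units; within the scatter), so a swap at this ring nitrogen also stays inside the scatter, even though the entering group has no ring and brings two hydrogen-bond acceptors where phenyl has none. Nothing given here offers a reason for the size of this step.

With only phenyl and tert-butoxycarbonyl on this nitrogen, and with the swap seen only on the chain of compound 2, the compounds shown leave open whether the same tolerance holds when the other end carries the 4-bromophenyl group of compound 3. They also leave open whether a free amine at this nitrogen, or a carboxylic acid on the phenyl ring, would move the number beyond the scatter, which no step shown so far has done.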